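Working notes on the step from compound 3 to compound 4

The source may report more compounds than this note shows. Statements on the series, on what has been measured and on what is new or still open speak of the compounds shown alone.

Values in a functional assay on A549 cells (Homo sapiens) for cytotoxicity, read by MTT assay, with a stated time of 72 h; a lower number here means a stronger inhibitor, a higher number a weaker inhibitor:
compound 1 `COc1ccc(OC)c(/C=C/C(=O)Nc2cc3c(Nc4ccc(F)c(Cl)c4)ncnc3cc2OC)c1`: 11200 nM
compound 2 `COc1cc2ncnc(Nc3ccc(F)c(Cl)c3)c2cc1NC(=O)/C=C/c1ccccc1[N+](=O)[O-]`: 33300 nM
compound 3 `COc1ccc(OC)c(/C=C/C(=O)Nc2cc3c(Nc4ccc(F)c(Cl)c4)ncnc3cc2O[C@H]2CCOC2)c1`: 7300 nM

Compound 3 holds the lowest number of the three; its gap to compound 1 is within the scatter, while compound 2 lies beyond it. Compound 4 `COc1cc(/C=C/C(=O)Nc2cc3c(Nc4ccc(F)c(Cl)c4)ncnc3cc2O[C@H]2CCOC2)cc(OC)c1O` is not yet measured. It differs from compound 3 in one place: 4-hydroxy-3,5-dimethoxyphenyl in place of 2,5-dimethoxyphenyl on a double-bonded chain carbon bound to a double-bonded chain carbon.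

One measured step changes the same place, the aryl group on the double-bonded chain carbon: a 3.0-fold higher number from compound 1 to compound 2 (0.47 log units; beyond the scatter). Within the data shown here, that step put 2-nitrophenyl in for 2,5-dimethoxyphenyl, a different group from the one entering here, so it says only that a swap at this place can move the number by a modest amount. The other step, a 1.5-fold lower number from compound 1 to compound 3 (0.19 log units; within the scatter), is at another place and does not bear on it. For compound 4 a step near or just beyond the scatter is expected, more likely upward than downward, a 1.4-fold higher number from compound 3 to compound 4 (0.14 log units; within the scatter). Compound 4 is therefore estimated at 10000 nM, between 4000 nM and 28000 nM.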

Compound 4, half-maximal inhibitory concentration: 27000 nM
Beside the measured number, compound 4's estimate is 2.7-fold (0.43 log units) below it; measured number inside the range.
By their numbers in this assay, from the lowest: compounds 3 and 1 (each within the scatter of the next); then compounds 4 and 2 (each within the scatter of the next).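

In this assay the aryl group on the double-bonded chain carbon now has a second step (a 3.7-fold higher number from compound 3 to compound 4 (0.57 log units; beyond the scatter)), with 4-hydroxy-3,5-dimethoxyphenyl in place of 2,5-dimethoxyphenyl. The earlier step at this place (a 3.0-fold higher number from compound 1 to compound 2 (0.47 log units; beyond the scatter)) ran the same way, so both replacements shown for 2,5-dimethoxyphenyl give a higher number, one with methyl on the oxygen on the aromatic ring and one with oxolan-3-yl there. Nothing measured here accounts for the rise.

The step changes the methoxy pattern and adds the hydroxy group at once, so 3,5-dimethoxyphenyl without the hydroxy would be needed to separate the two. From the compounds shown here alone, whether any group at this place, such as an aminophenyl or a pyridyl ring, gives a lower number than 2,5-dimethoxyphenyl remains open.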